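Compound 2 and a pyridine in place of phenyl

This account rests on a few compounds, and the source may have more. Where it says the series, first, only, none or still open, it means among the compounds named here.

Three compounds have been measured in an ADME assay on microsomes from liver (Mus musculus, strain CD-1) for metabolic stability, read by LC-MS, with a stated time of 60 min, tested at 20 uM; a lower number here means that the compound disappears faster, a higher number that the compound lasts longer:
compound 1 `CC(Sc1nc2nn(CC3COC3)cc2c(=O)n1-c1ccccc1)c1ccccc1`: 0.317 h
compound 2 `C[C@@H](Sc1nc2c(cnn2C)c(=O)n1-c1ccccc1)c1ccccc1`: 0.133 h
compound 3 `CC(Sc1nc2nn(C3COC3)cc2c(=O)n1-c1ccccc1)c1ccccn1`: > 1 h (a limit)

Compound 2 has the lowest number at 0.133 h, and the gap between it and compound 1, which gives 0.317 h, lies beyond the scatter. Compound 3 gives only a limit, > 1 h.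

Compound 4 `CC(Sc1nc2c(cnn2C)c(=O)n1-c1ccccc1)c1cccnc1` has not yet been measured. It carries 1-(pyridin-3-yl)ethyl in place of 1-phenylethyl on a sulfur. Among the measured compounds shown here, no measured pair isolates this change, so the expectation is tentative. In this assay, a rise beyond the scatter is expected, with an estimated 2.6-fold higher number from compound 2 to compound 4 (0.42 log units; beyond the scatter). The half-life of compound 4 is expected to be 0.35 h, with an estimated range of 0.15 h to 0.9 h.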

Compound 4, half-life: 0.117 h
Beside the measured number, compound 4's estimate is 3.0-fold (0.48 log units) above it, outside the stated range (below it).
By their numbers in this assay, from the lowest: compounds 4 and 2 (each within the scatter of the next); then compound 1. At a limit, above all of these: compound 3.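

In this assay, putting 1-(pyridin-3-yl)ethyl in place of 1-phenylethyl on a sulfur gives a 1.1-fold lower number from compound 2 to compound 4 (0.06 log units; within the scatter). Among the compounds shown here, this is the first pair to isolate the change, and it shows that this nitrogen in the ring leaves the half-life within the scatter at this position. Nothing shown gives a cause for this result.

Going by these compounds, it remains open whether 1-(pyridin-4-yl)ethyl, or an amine or a carboxylic acid on that ring, would move the number. On these data alone, it is also open whether the same change would behave alike in compound 1.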